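The source may hold more compounds than are shown below. What is called first, only, known or untested is meant among the compounds shown, and "the series" means these compounds.

Compound 3 `COc1cc(/C=C/C(C)=O)ccc1OCc1cn(-c2cc(F)cc(Br)c2)nn1` gives 56900 nM in a functional assay on PC-3 cells (Homo sapiens) for antiproliferative activity, read by MTT assay, with a stated time of 48 h; a lower number here means a stronger inhibitor, a higher number a weaker inhibitor. Among the three measured compounds it stands second highest: compound 2 `COc1cc(/C=C/C(C)=O)ccc1OCc1cn(-c2ccc(C=O)cc2)nn1` sits nearest with 80700 nM, and compound 1 `COc1cc(/C=C/C(C)=O)ccc1OCc1cn(-c2ccccc2OC)nn1` lies furthest with 2050 nM. The step of a 1.4-fold lower number from compound 2 to compound 3 (0.15 log units; within the scatter) is within the scatter, whereas the step of a 28-fold higher number from compound 1 to compound 3 (1.44 log units; beyond the scatter) is large, as is a 39-fold higher number from compound 1 to compound 2 (1.60 log units; beyond the scatter).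

Compound 4 `COc1cc(/C=C/C(C)=O)ccc1OCc1cn(-c2ccccc2O)nn1` arises from compound 3 by the change (2-hydroxyphenyl in place of 3-bromo-5-fluorophenyl on an aromatic nitrogen). For the measured compounds named here, the step that bears on it is the one from compound 1 to compound 3, because a 28-fold higher number from compound 1 to compound 3 (1.44 log units; beyond the scatter) shows how much the number rose when the 2-methoxyphenyl of compound 1 was exchanged for the 3-bromo-5-fluorophenyl; compound 4 returns to a phenyl bearing an oxygen at the same position, now as a hydroxyl. A large step downward in this assay is therefore expected, though whether the full gain of compound 1 is recovered is not known from these data. The estimated step is an 11-fold lower number from compound 3 to compound 4 (1.06 log units; beyond the scatter). Compound 4 is thus expected to give about 5000 nM, within a range from 1500 nM to 20000 nM.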

Compound 4, half-maximal inhibitory concentration: 59200 nM
Compound 4: middle estimate off by 12-fold (1.07 log units), on the low side, outside the stated range (above it).
By their numbers in this assay, from the lowest: compound 1; then compounds 3, 4 and 2 (each within the scatter of the next).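

The result shows that an oxygen on the phenyl ring is not enough in itself: in this assay, compound 4 with its 2-hydroxyphenyl cannot be told apart from the 3-bromo-5-fluorophenyl of compound 3 (a 1.0-fold higher number from compound 3 to compound 4 (0.02 log units; within the scatter)) or the 4-formylphenyl of compound 2 (a 1.4-fold lower number from compound 2 to compound 4 (0.13 log units; within the scatter)). What separates compound 4 from compound 1 is only the methyl on that oxygen, and this single exchange gives a large step (a 29-fold higher number from compound 1 to compound 4 (1.46 log units; beyond the scatter)), leaving compound 1 alone at the low end of the four. No measurement offered here accounts for this step.

On these data alone, it remains open whether the methyl itself is required or whether a 2-ethoxyphenyl or a longer chain on the oxygen would serve as well. A 2-aminophenyl or a 4-methoxyphenyl would test how far the number of compound 1 depends on the oxygen and on its place.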